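Ethoxy in Place of Pyrrolyl on a Shared Core

The compounds below may be only part of what the source reports. "The series", "measured", "known", "first", "only" and "open" are said of these compounds alone.

For the measured compounds named here, compound 2 `CN1CCN(CCCS(=O)(=O)c2ccc3nc(NC(=O)NC(=O)c4cc(-n5cccc5)ccc4Cl)sc3c2)CC1` gives 2.6 in a physicochemical assay for lipophilicity (a lower number here means a more polar compound, a higher number a more lipophilic compound), the higher of the two numbers measured so far. Going by the values given here, its neighbour is compound 1 `Cc1cc(C)n(-c2ccc(Cl)c(C(=O)NC(=O)Nc3nc4ccc(S(=O)(=O)CCCN5CCN(C)CC5)cc4s3)c2)n1`, which in this assay gives 2.5; the only measured step, a number 0.10 log units higher from compound 1 to compound 2 (within the scatter), is within the scatter. Compound 3 `CCOc1ccc(Cl)c(C(=O)NC(=O)Nc2nc3ccc(S(=O)(=O)CCCN4CCN(C)CC4)cc3s2)c1` has not yet been measured. The change from compound 2 to compound 3 is ethoxy in place of 1H-pyrrol-1-yl on an aromatic carbon. The step from compound 1 to compound 2 touches the same aromatic carbon, but it exchanges one five-membered aromatic ring for another and says little about an exchange for an ethoxy group. Among the compounds with values here, no measured pair therefore bears directly on this change, and the estimate rests on the structures alone. The writer expects compound 3 to show a step of a number 0.60 log units lower from compound 2 to compound 3 (beyond the scatter) in this assay, a modest move toward the polar side. He estimates compound 3 at 2, between 1.4 and 2.6.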

Compound 3, distribution coefficient: 2.4
The estimate for compound 3 lay 0.40 log units below the measured number, and the stated range covers the measured number.
By their numbers in this assay, from the lowest: compounds 3, 1 and 2 (each within the scatter of the next).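

In this assay, replacing the ring with ethoxy gives a number 0.20 log units lower from compound 2 to compound 3 (within the scatter) and, measured from the other ring, a number 0.10 log units lower from compound 1 to compound 3 (within the scatter). The earlier step had only exchanged one five-membered aromatic ring for another, whereas these two show that a group with no ring and fewer heavy atoms, on the same aromatic carbon para to a chloro group, still leaves the number within the scatter of both ring-bearing compounds. Nothing available accounts for how close the three numbers lie.

The compounds shown leave open whether an amine or a carboxylic acid on this aromatic carbon would also stay within the scatter of these three. They also leave open whether a longer chain in place of ethoxy would do so.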